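A Swap on the Sulfonyl Sulfur, Expected Within Scatter

The source may hold more compounds than are shown below. What is called first, only, known or untested is meant among the compounds shown, and "the series" means these compounds.

In a functional assay on KB cells (Homo sapiens) for antiproliferative activity, read by sulforhodamine B assay, with a stated time of 48 h (on this read-out higher numbers stand for weaker inhibition of growth and lower numbers for stronger inhibition of growth), compound 1 `COc1cccc(S(=O)(=O)Nc2ccccc2CCc2ccc(C(=O)Nc3ccccc3N)cc2)c1` gives 462 nM and compound 2 `Nc1ccccc1NC(=O)c1ccc(CCc2ccccc2NS(=O)(=O)c2ccc(Cl)cc2)cc1` gives 448 nM with only the aryl group on the sulfonyl sulfur differing. In this assay compound 3 `N#Cc1ccc(S(=O)(=O)Nc2ccccc2CCc2ccc(C(=O)Nc3ccccc3N)cc2)cc1` gives 790 nM and stands within the scatter of both others (a 1.7-fold higher number from compound 1 to compound 3 (0.23 log units; within the scatter) and a 1.8-fold higher number from compound 2 to compound 3 (0.25 log units; within the scatter)). The remaining pair is just as close (a 1.0-fold lower number from compound 1 to compound 2 (0.01 log units; within the scatter)). Compound 4 `COc1ccc(S(=O)(=O)Nc2ccccc2CCc2ccc(C(=O)Nc3ccccc3N)cc2)cc1OC` is reached through one change: 3,4-dimethoxyphenyl in place of 4-cyanophenyl on a sulfonyl sulfur in which 3,4-dimethoxyphenyl comes in place of 4-cyanophenyl on a sulfonyl sulfur. All three measured steps bear on this swap, and none of them leaves the scatter. Going by the values given here, the closest precedent is compound 1 (462 nM) with its 3-methoxyphenyl group. No step beyond the scatter is therefore expected, and the estimated size is small (a 1.5-fold lower number from compound 3 to compound 4 (0.18 log units; within the scatter)). The estimate for compound 4 is 520 nM (expected range 260 nM to 1050 nM).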

Compound 4, concentration for 50% growth inhibition: 888 nM
The estimate for compound 4 lay 1.7-fold (0.23 log units) below the measured number, within the range that was stated.
By their numbers in this assay, from the lowest: compounds 2, 1, 3 and 4 (each within the scatter of the next).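

In this assay the 3,4-dimethoxyphenyl group on the sulfonyl sulfur stays within the scatter of each aryl group shown earlier: the 4-cyanophenyl group (a 1.1-fold higher number from compound 3 to compound 4 (0.05 log units; within the scatter)), the 4-chlorophenyl group (a 2.0-fold higher number from compound 2 to compound 4 (0.30 log units; within the scatter)) and the 3-methoxyphenyl group, where methoxy takes the place of hydrogen (a 1.9-fold higher number from compound 1 to compound 4 (0.28 log units; within the scatter)). This adds a group with two methoxy substituents and a single-place methoxy change to the series, and neither gives a step beyond the scatter at this position. Nothing available here speaks to a cause for these small steps.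

All four compounds carry a substituted phenyl group on this sulfur. As far as these compounds go, whether a phenyl group bearing an amine or a carboxylic acid, or a longer alkyl chain in place of the phenyl group, would stay within the scatter remains open.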